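Swapping the Sulfamoylphenyl Arm of a Thiazole Acetic Acid

The source may hold more compounds than are shown below. What is called first, only, known or untested is meant among the compounds shown, and "the series" means these compounds.

Measured so far:
compound 1 `O=C(O)Cc1sc(C(c2ccccc2)c2ccc(Cl)cc2)nc1-c1ccc(F)cc1` — 14 nM
compound 2 `NS(=O)(=O)c1ccc(-c2nc(C(c3ccc(F)cc3)c3ccc(F)cc3)sc2CC(=O)O)cc1` — 1500 nM

In an in vitro assay on HEK385-7 cells for displacement of a labelled ligand from prostaglandin D2 receptor 2 (Homo sapiens) (on this read-out lower numbers stand for stronger inhibition and higher numbers for weaker inhibition), compound 2 gives 1500 nM, the higher of the two numbers here. Compound 1, which differs at several places, gives 14 nM, a gap far beyond the scatter, so compound 2 is the weaker binder of the pair.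

Compound 3 `CN(C)c1cc(-c2nc(C(c3ccc(F)cc3)c3ccc(F)cc3)sc2CC(=O)O)ccn1` has not yet been measured. It departs from compound 2 at one place: 2-(dimethylamino)pyridin-4-yl in place of 4-sulfamoylphenyl on an aromatic carbon. Nothing in the two measured values speaks directly to this swap, since compound 1 carries neither group.

Only a guess is possible. The change is estimated to bring a step of a 3.8-fold lower number from compound 2 to compound 3 (0.57 log units; beyond the scatter), toward a lower number, but its size is uncertain. Compound 3 is therefore expected to give about 400 nM in this assay, within a range from 60 nM to 3000 nM.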

Compound 3, half-maximal inhibitory concentration: 380 nM
Compound 3: middle estimate off by 1.1-fold (0.02 log units), on the high side; low and high end bracket the measured number.
By their numbers in this assay, from the lowest: compound 1; then compound 3; then compound 2.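

This position, on the aromatic carbon next to the ring nitrogen, clearly responds to the group it carries: in this assay the swap brings a 3.9-fold lower number from compound 2 to compound 3 (0.60 log units; beyond the scatter) and so shows that the 4-sulfamoylphenyl group is not required for binding at this level. The 2-(dimethylamino)pyridin-4-yl group has a hetero atom in its aromatic ring and no hydrogen-bond donors, but this single swap changes both features at once and cannot separate them. Nothing measured here explains the step.

From the compounds shown here alone, whether the dimethylamino group or the ring nitrogen matters more remains open, and a plain pyridin-4-yl group or a 4-(dimethylamino)phenyl group would help to tell them apart. Going by these compounds, it is also open how much of the remaining gap to compound 1 lies at this position, since compound 1 differs at several places.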